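Removing the carboxy group from compound 3

The source may hold more compounds than are shown below. What is called first, only, known or untested is meant among the compounds shown, and "the series" means these compounds.

Measured in a functional assay on MDA-MB-231 cells (Homo sapiens) for inhibition, read by MTT assay, with a stated time of 72 h; a lower number here means a stronger inhibitor, a higher number a weaker inhibitor:
- Compound 1 `CC(C)=CCC[C@H](C)c1ccc(C)c(CNCC2CCNCC2)c1O`: 18300 nM
- Compound 2 `CC(C)=CCC[C@H](C)c1ccc(C)c(CNCCCCCO)c1O`: 10700 nM
- Compound 3 `CC(C)=CCC[C@H](C)c1ccc(C)c(CNCCCCC(=O)O)c1O`: > 50000 nM (a limit)

Compound 3 is the only one of the three reported as a limit, not as a number: the limit of > 50000 nM in this assay, at which 1 of the 3 values shown sits. Its true position is therefore open on one side. The next compound to be tested is compound 4 `CCOC(CCNCc1c(C)ccc([C@@H](C)CCC=C(C)C)c1O)OCC`, which differs from compound 3 at a single place. diethoxymethyl in place of 2-carboxyethyl on a saturated chain carbon, two bonds along the chain from an amine nitrogen In words, diethoxymethyl stands in place of 2-carboxyethyl on a saturated chain carbon, two bonds along the chain from an amine nitrogen.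

For the measured compounds named here, two measured steps bear most directly on this change, since both introduce the carboxy-bearing chain: an at least 4.6-fold higher number from compound 2 to compound 3 (0.66 log units; beyond the scatter) and an at least 2.7-fold higher number from compound 1 to compound 3 (0.43 log units; beyond the scatter). The step of a 1.7-fold lower number from compound 1 to compound 2 (0.23 log units; within the scatter) shows that these two compounds without a carboxy group stay within the scatter of each other, despite their different groups. Going by the values given here, no measured compound carries diethoxymethyl, so the comparison is only an approximate guide. A step toward a lower number is therefore expected in this assay, estimated as an at least 3.3-fold lower number from compound 3 to compound 4 (0.52 log units; beyond the scatter). For compound 4 the expected value is 15000 nM, with an estimated range of 6000 nM to 40000 nM.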

Compound 4, half-maximal inhibitory concentration: 14900 nM
The estimate for compound 4 lay 1.0-fold (0.00 log units) above the measured number, and the stated range covers the measured number.
By their numbers in this assay, from the lowest: compounds 2, 4 and 1 (each within the scatter of the next). At a limit, above all of these: compound 3.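

In this assay, the change from 2-carboxyethyl to diethoxymethyl at this place, on a saturated chain carbon two bonds along the chain from an amine nitrogen, brings an at least 3.3-fold lower number from compound 3 to compound 4 (0.52 log units; beyond the scatter). The value of compound 3 is a limit, not a number: the limit of > 50000 nM in this assay, at which 1 of the 4 values shown sits. Compound 4 also falls in with the two other compounds that lack a carboxy group, with a 1.4-fold higher number from compound 2 to compound 4 (0.14 log units; within the scatter) and a 1.2-fold lower number from compound 1 to compound 4 (0.09 log units; within the scatter), so three different chain ends now sit within the scatter of one another, and among the compounds shown only the carboxy-bearing compound 3 stands apart, with no compound going against this.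

The compounds shown leave open where the true value of compound 3 lies, and so the full size of its step to compound 4. They also leave open whether an ethyl ester on the same chain would stay with compound 3 or join compound 4, and whether a primary amine or a longer chain at this place would stay within the scatter of compound 2, compound 4 and compound 1.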